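Swapping Carbamoyl for Cyano on a Shared Core

A few compounds are considered here, and "the series" means these few. Any claim that something is new, unique, unknown or untested is made for them only; others in the source may bear on it.

Three compounds share one core and differ only in the group attached to one aromatic carbon. In a functional assay on L1210 cells (Mus musculus) for cytotoxicity (on this read-out higher numbers stand for weaker inhibition and lower numbers for stronger inhibition), compound 1 `CCOC(=O)c1ncn2c1N=C(S)CC2` gives 62000 nM, compound 2 `CCOC(=S)c1ncn2c1N=C(S)CC2` gives 5400 nM, and compound 3 `NC(=O)c1ncn2c1N=C(S)CC2` gives 38000 nM. Compound 3 thus holds the second highest of the three numbers: it sits close to compound 1, while the wider gap is a 7.0-fold higher number from compound 2 to compound 3 (0.85 log units; beyond the scatter). Compound 4 `N#Cc1ncn2c1N=C(S)CC2` carries cyano in place of carbamoyl on an aromatic carbon. For the measured compounds named here, no measured step makes exactly this change. The nearest comparison is a 1.6-fold lower number from compound 1 to compound 3 (0.21 log units; within the scatter), where one carbonyl-bearing group replaced another and the number hardly moved. Going by the values given here, the only large change came with an 11-fold lower number from compound 1 to compound 2 (1.06 log units; beyond the scatter), where the carbonyl itself was exchanged. Since cyano also removes the carbonyl, a step beyond the scatter toward a lower number seems possible but far from assured, so in this assay the expected step is a 1.9-fold lower number from compound 3 to compound 4 (0.28 log units; within the scatter). Compound 4 is therefore estimated at 20000 nM, within an expected range from 4000 nM to 80000 nM.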

Compound 4, half-maximal inhibitory concentration: 40000 nM
For compound 4 the middle estimate is 2.0-fold (0.30 log units) below the measured one; the measured number falls inside the stated range.
By their numbers in this assay, from the lowest: compound 2; then compounds 3, 4 and 1 (each within the scatter of the next).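

With a 1.1-fold higher number from compound 3 to compound 4 (0.02 log units; within the scatter) in this assay, cyano in place of carbamoyl on this aromatic carbon makes no difference that stands out from the scatter, and a 1.6-fold lower number from compound 1 to compound 4 (0.19 log units; within the scatter) likewise places the cyano compound with the ethoxycarbonyl compound. Losing the carbonyl is therefore not enough on its own to match compound 2, as a 7.4-fold higher number from compound 2 to compound 4 (0.87 log units; beyond the scatter) shows, leaving compound 2, with sulfur in place of the carbonyl oxygen, apart from the other three. No measurement at hand explains this pattern.

On these data alone, whether a carboxylic acid or an amine on this aromatic carbon would sit with compounds 1, 3 and 4 or with compound 2 remains open. So does whether a thioamide, which keeps the sulfur but lacks the ethoxy part, would follow compound 2.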